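This account rests on a few compounds, and the source may have more. Where it says the series, first, only, none or still open, it means among the compounds named here.

Measured compounds:
compound 1, `COc1ccc(-c2c(C)nn3c(N4CCCC4)nc(C)nc23)c(C)c1`, 80.7 nM
compound 2, `CCCCN(CC)c1nc(C)nc2c(-c3ccc(OC)cc3C)c(C)nn12`, 2.3 nM

In an assay on cell membranes for displacement of a labelled ligand from corticotropin-releasing factor receptor 1 (Rattus norvegicus) (a lower number here means a stronger inhibitor, a higher number a weaker inhibitor), compound 1 gives 80.7 nM, while compound 2 gives 2.3 nM, the lowest of the two numbers in this assay. Within the data shown here, the only measured step, a 35-fold lower number from compound 1 to compound 2 (1.55 log units; beyond the scatter), came from the change to butyl(ethyl)amino in place of pyrrolidin-1-yl on an aromatic carbon, and shows that the group at this position moves the number strongly.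

Compound 3, `COc1ccc(-c2c(C)nn3c(N(CCC#N)C4CC4)nc(C)nc23)c(C)c1`, differs from compound 2 by (2-cyanoethyl)(cyclopropyl)amino in place of butyl(ethyl)amino on an aromatic carbon. Among the measured compounds shown here, no measured pair shows this particular exchange, so the step from compound 1 to compound 2 bears on it only in pointing to the same position as sensitive. Because compound 2 already gives 2.3 nM, compound 3 is expected to remain a strong inhibitor, with a modest step of a 2.2-fold higher number from compound 2 to compound 3 (0.34 log units; beyond the scatter) expected. Compound 3 is estimated at 5 nM, in a range from 1.5 nM to 20 nM.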

Compound 3, half-maximal inhibitory concentration: 1.88 nM
Compound 3: middle estimate off by 2.7-fold (0.42 log units), on the high side, within the range that was stated.
By their numbers in this assay, from the lowest: compounds 3 and 2 (each within the scatter of the next); then compound 1.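

In this assay, the step of a 1.2-fold lower number from compound 2 to compound 3 (0.09 log units; within the scatter) shows that this position accepts two quite different open amines on equal terms: (2-cyanoethyl)(cyclopropyl)amino, with its three-membered ring and triple bond, does as well as butyl(ethyl)amino. Among these compounds, the step of a 43-fold lower number from compound 1 to compound 3 (1.63 log units; beyond the scatter) has about the same size as the earlier step from pyrrolidin-1-yl, so the low number is not tied to butyl(ethyl)amino alone, and compound 1 remains the one compound apart. Nothing available explains why these two groups stand level.

The compounds shown leave open what the nitrile and the cyclopropyl ring each contribute, since they enter together in one group. They also leave open how a piperidin-1-yl ring or a dipropylamino group would fare on this aromatic carbon.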